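Dihalophenyl swap at the aryl position: stability notes

A few compounds are considered here, and "the series" means these few. Any claim that something is new, unique, unknown or untested is made for them only; others in the source may bear on it.

Compound 1 `N#Cc1ccc(-c2nc(NCCNc3ccc([N+](=O)[O-])c(N)n3)ncc2-c2ncc[nH]2)cc1` has been measured in an ADME assay on microsomes from liver (Canis lupus familiaris) for metabolic stability; a lower number here means that the compound disappears faster, a higher number that the compound lasts longer. In this assay compound 1 gives > 0.5 h, which is a limit of the assay and not a number. Compound 2 `Nc1nc(NCCNc2ncc(-c3ncc[nH]3)c(-c3ccc(Cl)cc3F)n2)ccc1[N+](=O)[O-]` carries 4-chloro-2-fluorophenyl in place of 4-cyanophenyl on an aromatic carbon. In this assay compound 2 gives > 0.5 h, again a limit rather than a number. The step that the two limits leave unreadable from compound 1 to compound 2 is for that reason not readable in size. Both values shown sit at the limit of > 0.5 h in this assay, at which 2 of the 2 values shown sit, so where compound 1 stands on the numbers can only be given as that limit.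

Compound 3 `Nc1nc(NCCNc2ncc(-c3ncc[nH]3)c(-c3ccc(Br)cc3Cl)n2)ccc1[N+](=O)[O-]` is not yet measured in this assay. Among the measured compounds shown here, it differs from compound 1 as follows: 4-bromo-2-chlorophenyl in place of 4-cyanophenyl on an aromatic carbon The one measured step, from compound 1 to compound 2, bears on this change, since both exchange 4-cyanophenyl on the same aromatic carbon, but its size is unreadable. No step beyond the scatter is shown in either direction; the expectation for compound 3 is a step that the limit leaves unreadable from compound 1 to compound 3 of no readable size, most likely ending again at the limit. Compound 3 is estimated at 1 h, with a range from 0.5 h to 3 h.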

Compound 3, half-life: > 0.5 h
Compound 3 was reported as a limit (the forecaster's own chance of this, stated with the estimate: 80%); the middle value lies beyond the limit too.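

In this assay compound 3 gives > 0.5 h, which is a limit of the assay and not a number. The steps from compound 3 to compound 1 and compound 2 therefore cannot be read, and no comparison follows: the limit of > 0.5 h in this assay, at which 3 of the 3 values shown sit.

The compounds shown leave open how far compound 1, compound 2 and compound 3 lie beyond that limit, and whether 4-cyanophenyl, 4-chloro-2-fluorophenyl and 4-bromo-2-chlorophenyl differ at all in this assay.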